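Series notes: removing the aryl group to give compound 4

The source may report more compounds than this note shows. Statements on the series, on what has been measured and on what is new or still open speak of the compounds shown alone.

Measured compounds:
Compound 1 `COc1ccc2nccc(C3CN(C4CCN(Cc5c[nH]c6ccccc56)CC4)C(=O)O3)c2c1`: in an in vitro functional assay on RBL cells for antagonist activity at C-C chemokine receptor type 8 (Homo sapiens), read by FLIPR and calcium flux (a higher number here means a weaker inhibitor, a lower number a stronger inhibitor), compound 1 reads < 50200 nM, which is a limit of the assay and not a number.
Compound 2 `COc1ccc2nccc(C3CN(C4CCN(Cc5cc6ccccc6s5)CC4)C(=O)O3)c2c1`: compound 2 gives 794 nM.
Compound 3 `COc1ccc2nccc(C3CN(C4CCN(Cc5ccc6ccccc6c5)CC4)C(=O)O3)c2c1`: compound 3 gives 1260 nM.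

Compound 3 holds the highest of the two numbers read; its nearest neighbour is compound 2, reached by a 1.6-fold higher number from compound 2 to compound 3 (0.20 log units; within the scatter). The step that the limit leaves unreadable from compound 1 to compound 3 cannot be sized; (the limit of < 50200 nM in this assay, at which 1 of the 3 values shown sits).

Compound 4 `COc1ccc2nccc(C3CN(C4CCN(C)CC4)C(=O)O3)c2c1` differs from compound 3 by hydrogen in place of naphthalen-2-yl on a saturated chain carbon bound to an amine nitrogen in a ring. Among the measured compounds shown here, no measured step matches this change. The steps that can be compared only swap one bicyclic aryl group for another: a 1.6-fold higher number from compound 2 to compound 3 (0.20 log units; within the scatter) lies within the scatter, and a step that the limit leaves unreadable from compound 1 to compound 2 stays unreadable. Removing the aryl group entirely, leaving a methyl on that carbon, is therefore an untested move, and the outcome is uncertain. The working expectation is a clearly weaker inhibitor, with a real chance that only a limit is returned.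

Compound 4 is expected to give 20000 nM, with a range from 4000 nM to 100000 nM. This estimate means an expected step of a 16-fold higher number from compound 3 to compound 4 (1.20 log units; beyond the scatter) in this assay.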

Compound 4, half-maximal inhibitory concentration: < 50200 nM
Compound 4 was reported as a limit; the forecaster's own chance of this, stated with the estimate: 40%; the middle value does not contradict the limit.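

Compound 4 gives < 50200 nM as a limit of the assay and not a number. No step from compound 1, compound 2 or compound 3 to compound 4 can be read: the limit of < 50200 nM in this assay, at which 2 of the 4 values shown sit.

Left open is how far the number in this assay moves when hydrogen replaces naphthalen-2-yl on that carbon, and whether compound 1 and compound 4 differ at all.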